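The source may report more compounds than this note shows. Statements on the series, on what has been measured and on what is new or still open speak of the compounds shown alone.

Measured so far in a functional assay on the whole organism with Mus musculus as the target; a higher number here means that more compound is needed for the effect, a lower number that less compound is needed:

- compound 1 `CC[C@@H](C(=O)Nc1ccccc1)N1CCCC1=O`: 560 umol/kg
- compound 2 `CC[C@@H](C(=O)N(C)OC)N1CCCC1=O`: 1000 umol/kg

Compound 2 (1000 umol/kg) and compound 1 (560 umol/kg) lie within the usual scatter of each other. On these numbers they cannot be told apart in this assay even though they carry different groups on the carbonyl carbon.

Compound 3 `CC[C@@H](C(=O)NO)N1CCCC1=O` has not yet been measured. It has hydroxyamino in place of methoxy(methyl)amino on a carbonyl carbon. For the measured compounds named here, no measured pair differs in one place only, so there is no direct guide to the size of this change, and two compounds are a thin basis for any forecast. The expected step of a 1.3-fold lower number from compound 2 to compound 3 (0.10 log units; within the scatter) stays within the scatter, with no clear direction. For compound 3 the estimated value is 800 umol/kg with an expected range from 250 umol/kg to 2000 umol/kg in this test.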

Compound 3, dose for half-maximal effect: 1000 umol/kg
For compound 3 the middle estimate is 1.3-fold (0.10 log units) below the measured one, and the stated range covers the measured number.
By their numbers in this assay, from the lowest: compounds 1, 2 and 3 (each within the scatter of the next).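

In this assay, hydroxyamino in place of methoxy(methyl)amino on a carbonyl carbon gives no change at the digits printed from compound 2 to compound 3 (within the scatter), although the group goes from 4 heavy atoms to 2 and from 0 hydrogen-bond donors to 2. Hydroxy in place of phenyl on an amide-type nitrogen gives a 1.8-fold higher number from compound 1 to compound 3 (0.25 log units; within the scatter), so these first single-place comparisons show that even a swap as large as losing a ring leaves the numbers impossible to tell apart at this position. No measurement shown here explains this insensitivity.

Going by these compounds, it remains open whether any group on this carbonyl carbon can move the number beyond the scatter. A carboxylic acid or a longer chain in that place would test this, in either direction.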